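The source may report more compounds than this note shows. Statements on the series, on what has been measured and on what is new or still open speak of the compounds shown alone.

Measured so far in an ADME assay on L6 cells (Rattus norvegicus) for cytotoxicity, read by resazurin assay, with a stated time of 72 h; a higher number here means a weaker inhibitor, a lower number a stronger inhibitor:
- compound 1 `N=C(N)c1cccc(OCc2ccccc2)c1`: 156000000 nM
- compound 2 `N=C(N)c1cccc(OCc2cccc([N+](=O)[O-])c2)c1`: 78900000 nM
- compound 3 `N=C(N)c1cccc(COc2cccc([N+](=O)[O-])c2)c1`: 104000000 nM

The three values sit close together. Within the data shown here, at 104000000 nM, compound 3 lies within the scatter of both compound 1 and compound 2, so the series so far offers no clear ordering in this assay.

The next structure is compound 4 `N=C(N)c1cccc(COc2cccc(C(=N)N)c2)c1`, which is reached from compound 3 by a group of 3 heavy atoms (1 carbon, 2 nitrogen; no ring) in place of a group of 3 heavy atoms (1 nitrogen, 2 oxygen; no ring), on an aromatic carbon. Among the measured compounds shown here, only one measured step bears on this change: a 2.0-fold lower number from compound 1 to compound 2 (0.30 log units; within the scatter). That step, nitro in place of hydrogen on an aromatic carbon, stays within the scatter, so it shows that this position tolerates a nitro group without a clear shift in the read-out. For the measured compounds named here, it says nothing direct about the group entering here, and no measured step covers this replacement. With so little evidence, no step beyond the scatter is expected, and the uncertainty remains wide in both directions.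

For compound 4 the expected value is 80000000 nM, with an estimated range from 25000000 nM to 200000000 nM. This estimate means an expected 1.3-fold lower number from compound 3 to compound 4 (0.11 log units; within the scatter).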

Compound 4, half-maximal inhibitory concentration: 24000000 nM
Beside the measured number, compound 4's estimate is 3.3-fold (0.52 log units) above it; measured number below the stated range.
By their numbers in this assay, from the lowest: compound 4; then compounds 2, 3 and 1 (each within the scatter of the next).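

In this assay, among these compounds, this position, on an aromatic carbon of a six-membered aromatic ring of carbon only, proves sensitive to the group placed there: nitro in place of hydrogen gave no shift beyond the scatter, but the replacement of nitro by the group of 3 heavy atoms (1 carbon, 2 nitrogen; no ring) gives a 4.3-fold lower number from compound 3 to compound 4 (0.64 log units; beyond the scatter) and so separates a compound from the series for the first time. The separation holds against the other two compounds, with a 3.3-fold lower number from compound 2 to compound 4 (0.52 log units; beyond the scatter) and with a 6.5-fold lower number from compound 1 to compound 4 (0.81 log units; beyond the scatter), which leaves compound 4 with the lowest number of the four. No measurement at hand accounts for this shift.

Open, as far as these compounds go, is whether the shift is specific to this group or would also appear with an amine, a carboxylic acid or a nitrile at the same position. Also open, from the compounds shown here alone, is whether the group gives a similar step when the linker runs in the reversed order seen in compound 2, and how a longer chain in that linker would alter the read-out.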